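The compounds below may be only part of what the source reports. "The series", "measured", "known", "first", "only" and "open" are said of these compounds alone.

In an assay for inhibition of MAP kinase-interacting serine/threonine-protein kinase 1 (Homo sapiens), read by luminescence and ADP-Glo, with a stated time of 2 h (a lower number here means a stronger inhibitor, a higher number a weaker inhibitor), compound 1 `NC(=O)c1cccc(Cn2cc(-c3ccc4cn[nH]c4c3)ccc2=O)c1` gives 388 nM, the highest of the two numbers recorded; compound 2 `Nc1n[nH]c2cc(-c3ccc(=O)n(Cc4ccccc4F)c3)ccc12` gives 12 nM, a far lower number, beyond the usual scatter. Compound 3 `CC(=O)Nc1cccc(Cn2cc(-c3ccc4cn[nH]c4c3)ccc2=O)c1` differs from compound 1 in one place: acetamido in place of carbamoyl on an aromatic carbon. Within the data shown here, no measured pair shows this change, so the size of its step is unknown; the change keeps one hydrogen-bond donor and one hydrogen-bond acceptor in place. Relative to compound 1, compound 3 is expected to show only a modest step, a 1.3-fold higher number from compound 1 to compound 3 (0.11 log units; within the scatter), if anything toward a higher number. The estimate for compound 3 in this assay is 500 nM, between 150 nM and 1600 nM.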

Compound 3, half-maximal inhibitory concentration: 163 nM
Estimate against measurement, compound 3: 3.1-fold (0.49 log units) above; low and high end bracket the measured number.
By their numbers in this assay, from the lowest: compound 2; then compound 3; then compound 1.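

In this assay, acetamido in place of carbamoyl on this aromatic carbon gives a 2.4-fold lower number from compound 1 to compound 3 (0.38 log units; beyond the scatter) and so moves the number toward a stronger inhibitor. This position, meta to a large group, therefore accepts the larger acetamido group without a loss, and the number moves even though the two groups match in hydrogen-bond donors and acceptors. No measurement at hand explains this step.

From the compounds shown here alone, whether a longer chain on the carbonyl would lower the number further remains open. So does the effect of an amine or a carboxylic acid at this place.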